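The compounds below may be only part of what the source reports. "The series", "measured", "known", "first", "only" and "open" are said of these compounds alone.

In a functional assay on B16 cells (Mus musculus) for inhibition, with a stated time of 72 h (a higher number here means a weaker inhibitor, a lower number a stronger inhibitor), compound 1 (`S=C1NCCN1Cc1ccc(Cl)cc1`) gives 4300 nM and compound 2 (`S=C1NCCCN1CCCc1ccccc1`) gives 2100 nM. Compound 3 (`O=C1NCCCN1Cc1ccccc1`) has no exact number: its > 10000 nM is a limit of the assay. Going by these compounds, it therefore stands at the weak end of the three measured compounds, although how weak it really is remains unknown.

Compound 4 (`CC(C)c1ccc(CN2CCCNC2=O)cc1`) is built from compound 3 by one change: an isopropyl in place of hydrogen on an aromatic carbon. Among the measured compounds shown here, no measured pair of compounds shows what this change does, so any forecast is uncertain. A small move towards stronger inhibition is expected, or none beyond the usual scatter. Compound 2 at 2100 nM shows that this series can give a number within the range of this assay. The result for compound 4 may well again be only a limit. The expected change is an at least 1.1-fold lower number from compound 3 to compound 4 (0.04 log units; that floor lies within the scatter). The estimated value for compound 4 is 9000 nM, with an expected range from 3000 nM to 30000 nM.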

Compound 4, half-maximal inhibitory concentration: > 10000 nM
Compound 4: no number, only a limit; the forecaster's own chance of this, stated with the estimate: 50%; at least 1.1-fold (0.04 log units) between middle value and limit.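

Compound 3 and compound 4 each give only a limit of the assay, not a number, so no step can be read from this pair: (the limit of > 10000 nM in this assay, at which 2 of the 4 values shown sit). The compounds shown leave open whether the isopropyl changes inhibition at all, and how weak either compound really is.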